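Swapping a Piperazine for a Pyrazole on a Urea

The source may report more compounds than this note shows. Statements on the series, on what has been measured and on what is new or still open speak of the compounds shown alone.

Measured so far:
compound 1, `Cc1cc(C)c(NC(=O)N(Cc2ccc(N3CCN(C)CC3)cc2)C2CCCCCC2)c(C)c1`: 57 nM
compound 2, `CSc1cc(C)nc(SC)c1NC(=O)N(Cc1ccccc1)Cc1cccc(-c2ccnn2C)c1`: 28 nM

Both compounds were tested in an assay on microsomes from intestine for inhibition of acyl-CoA:cholesterol acyltransferase (Oryctolagus cuniculus); a higher number here means a weaker inhibitor, a lower number a stronger inhibitor. Compound 1 has the higher of the two numbers, and the gap between compound 1 and compound 2 lies beyond the usual scatter, so compound 2 is the stronger inhibitor of the pair. The two structures differ in many places at once, so no single change can be tied to that gap.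

Compound 3, `Cc1cc(C)c(NC(=O)N(Cc2ccc(-c3cnn(C)c3)cc2)C2CCCCCC2)c(C)c1`, is a close relative of compound 1. It differs in one place: 1-methyl-1H-pyrazol-4-yl in place of 4-methylpiperazin-1-yl on an aromatic carbon. The rest of the structure is kept. Compound 2 also carries a methylpyrazole on its benzyl group, though no one-change comparison exists to show what such a group does on its own.

The expected step from compound 1 to compound 3, a 1.4-fold lower number from compound 1 to compound 3 (0.15 log units; within the scatter), is small and leans toward a lower number. Compound 3 is therefore estimated at 40 nM, within a range from 12 nM to 130 nM.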

Compound 3, half-maximal inhibitory concentration: 47 nM
The estimate for compound 3 lay 1.2-fold (0.07 log units) below the measured number, within the range that was stated.
By their numbers in this assay, from the lowest: compounds 2, 3 and 1 (each within the scatter of the next, the first and the last beyond it).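

In this assay, putting 1-methyl-1H-pyrazol-4-yl in place of 4-methylpiperazin-1-yl gives a 1.2-fold lower number from compound 1 to compound 3 (0.08 log units; within the scatter). Among these compounds, this is the first comparison here that isolates one change, and it shows that, at this place on the aromatic ring, para to a large group, a six-membered non-aromatic ring and a five-membered aromatic ring give numbers that cannot be told apart, while the counts of hydrogen-bond donors and acceptors stay the same. Nothing measured here explains why the two groups read alike.

Going by these compounds, it remains open whether this place needs a ring at all, which a smaller group such as dimethylamino or a charged one such as a carboxylic acid could test. On these data alone, it is also open whether the same exchange would read alike on the core of compound 2.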